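The source may report more compounds than this note shows. Statements on the series, on what has been measured and on what is new or still open speak of the compounds shown alone.

Measured in a functional assay on MOLT-4 cells (Homo sapiens) for inhibition, read by MTT assay, with a stated time of 72 h; a higher number here means a weaker inhibitor, a lower number a stronger inhibitor:
- compound 1 `COc1cc(NC(C)CCCNC(=O)Nc2cccc(F)c2)c2ncccc2c1`: 23000 nM
- compound 2 `COc1cc(NC(C)CCCNC(=O)Nc2cccc(O)c2)c2ncccc2c1`: 24000 nM

With only these two numbers in this assay, compound 2 stands level with compound 1, the gap between them lying within the scatter. The next compound is compound 3 `COc1cc(NC(C)CCCNC(=O)NNC(=O)Nc2ccc(O)cc2)c2ncccc2c1`, with this change from compound 2: ((4-hydroxyphenyl)carbamoyl)amino in place of 3-hydroxyphenyl on an amide-type nitrogen. In words, ((4-hydroxyphenyl)carbamoyl)amino comes in place of 3-hydroxyphenyl on an amide-type nitrogen. Going by the values given here, the only measured step, hydroxy in place of fluoro on an aromatic carbon, is a 1.0-fold higher number from compound 1 to compound 2 (0.02 log units; within the scatter). Among the compounds with values here, that step is small, but it does not cover a replacement of this kind, and no measured compound carries the entering group. The data therefore fix no direction, and only a modest move to a lower number is expected, with wide uncertainty. The expected step is a 1.6-fold lower number from compound 2 to compound 3 (0.20 log units; within the scatter). For compound 3 the estimated value is 15000 nM, with an expected range of 4000 nM to 45000 nM.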

Compound 3, half-maximal inhibitory concentration: 104000 nM
Compound 3: the middle estimate sits 6.9-fold (0.84 log units) below what was measured; the whole stated range lies below it.
By their numbers in this assay, from the lowest: compounds 1 and 2 (each within the scatter of the next); then compound 3.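

Notes on the amide-type nitrogen, read in this assay: this is the first change in the series to move the number beyond the scatter, since ((4-hydroxyphenyl)carbamoyl)amino in place of 3-hydroxyphenyl gives a weaker inhibitor (a 4.3-fold higher number from compound 2 to compound 3 (0.64 log units; beyond the scatter)). The same entering group in place of 3-fluorophenyl gives a step of similar size (a 4.5-fold higher number from compound 1 to compound 3 (0.66 log units; beyond the scatter)), so the loss appears from either of the two aryl groups that leave, whereas the swap of fluoro for hydroxy on the ring left the number level. No measurement on hand accounts for this loss.

The replacement lengthens the link to the ring and also carries a 4-hydroxy rather than a 3-hydroxy ring, and these two changes remain unseparated. Also open, on these data alone, is how an amine on the aromatic ring, or a carboxylic acid there, would read at this position.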